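This account rests on a few compounds, and the source may have more. Where it says the series, first, only, none or still open, it means among the compounds named here.

In an ADME assay on MT4 cells (Homo sapiens) for cytotoxicity, read by MTT assay (a higher number here means that more compound is tolerated, a lower number that less compound is tolerated), three compounds sharing one core have been measured:

Compound 1 `Cc1cc(C)cc(S(=O)(=O)c2c(C(=O)NCc3ccccc3N)[nH]c3ccc(Cl)cc23)c1`: 46200 nM
Compound 2 `Cc1cc(C)cc(S(=O)(=O)c2c(C(=O)NC(C)c3ccccc3O)[nH]c3ccc(Cl)cc23)c1`: 21800 nM
Compound 3 `Cc1cc(C)cc(S(=O)(=O)c2c(C(=O)NCc3ccc(O)cc3)[nH]c3ccc(Cl)cc23)c1`: 6250 nM

Compound 1 stands highest of the three numbers, with compound 2 nearest to it, a 2.1-fold lower number from compound 1 to compound 2 (0.33 log units; beyond the scatter), and compound 3 furthest, a 7.4-fold lower number from compound 1 to compound 3 (0.87 log units; beyond the scatter). Between the two lower compounds there is a 3.5-fold lower number from compound 2 to compound 3 (0.54 log units; beyond the scatter).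

Compound 4 `Cc1cc(C)cc(S(=O)(=O)c2c(C(=O)NCC(=O)NCc3cccc(O)c3)[nH]c3ccc(Cl)cc23)c1` has not yet been measured in this assay. It differs from compound 1 in one place: (3-hydroxybenzyl)carbamoyl in place of 2-aminophenyl on a saturated chain carbon bound to an amide-type nitrogen. Among the compounds with values here, of the measured steps, the one from compound 1 to compound 3 bears most directly on this change, since it also removes the 2-aminophenyl group from the same saturated chain carbon and brings in a hydroxyl-bearing aromatic ring, and it was modest but beyond the scatter. The steps involving compound 2 point the same way, both lowering the number. Every change away from compound 1 measured so far has lowered the number, so a lower number is expected for compound 4 as well, in a modest step, a 3.1-fold lower number from compound 1 to compound 4 (0.49 log units; beyond the scatter). The (3-hydroxybenzyl)carbamoyl group is larger than anything yet tried here, which leaves the size of that step uncertain. Compound 4 is therefore estimated at 15000 nM, within a range from 5000 nM to 45000 nM.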

Compound 4, half-maximal cytotoxic concentration: > 47500 nM
Compound 4 was reported as a limit (the forecaster's own chance of this, stated with the estimate: 10%); middle value at least 3.1-fold (0.50 log units) away from the limit.
By their numbers in this assay, from the lowest: compound 3; then compound 2; then compound 1. At a limit, above all of these: compound 4.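

In this assay, compound 4 stands only as a limit of the assay: the limit of > 47500 nM in this assay, at which 1 of the 4 values shown sits. Putting (3-hydroxybenzyl)carbamoyl in place of 2-aminophenyl, on a saturated chain carbon bound to an amide-type nitrogen, is the first change shown that does not lower the number, although the step, an at least 1.0-fold higher number from compound 1 to compound 4 (0.01 log units; that floor lies within the scatter), gives no order for that pair. This place therefore accepts the larger group without a measured loss, and the other two steps do stand clear: an at least 7.6-fold higher number from compound 3 to compound 4 (0.88 log units; beyond the scatter), and an at least 2.1-fold higher number from compound 2 to compound 4 (0.33 log units; beyond the scatter).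

The limit leaves open how high the true number of compound 4 lies. From the compounds shown here alone, it also remains open whether a benzylcarbamoyl group without the hydroxyl, or a carboxylic acid on the same saturated chain carbon, would give a number as high.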